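Sulfonyl-amide tail variation: carbamate replaced by benzylamine

The source may hold more compounds than are shown below. What is called first, only, known or untested is meant among the compounds shown, and "the series" means these compounds.

Measured so far:
compound 1, `CC(C)(C)NC(=O)NCCS(=O)(=O)NC(=O)c1ccc(Nc2nc(NC3(c4ccc(Cl)cc4)CC3)nc(OCC(F)(F)F)n2)cc1`: in an ADME assay on microsomes from liver (Rattus norvegicus) for metabolic stability, with a stated time of 10 min (a higher number here means that more of the compound is left, a lower number that less of the compound is left), compound 1 gives 93%.
compound 2, `O=C(NS(=O)(=O)CCNC(=O)C1CC1)c1ccc(Nc2nc(NC3(c4ccc(Cl)cc4)CC3)nc(OCC(F)(F)F)n2)cc1`: in this assay compound 2 gives "not active" (no number reported).
compound 3, `CC(C)OC(=O)NCCS(=O)(=O)NC(=O)c1ccc(Nc2nc(NC3(c4ccc(Cl)cc4)CC3)nc(OCC(F)(F)F)n2)cc1`: in this assay compound 3 gives 73%.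

Among the measured compounds shown here, compound 3 holds the lower of the two numbers reported; the only step with numbers on both sides, a number 20 percentage points lower from compound 1 to compound 3 (beyond the scatter), lies beyond the scatter. Compound 2 returned no number at all, so its position cannot be ranked.

Compound 4, `O=C(NS(=O)(=O)CCNCc1ccccc1)c1ccc(Nc2nc(NC3(c4ccc(Cl)cc4)CC3)nc(OCC(F)(F)F)n2)cc1`, differs from compound 3 only at the tail on the sulfonamide side chain: benzyl in place of isopropoxycarbonyl on an amine nitrogen. For the measured compounds named here, no measured pair shows this exchange. Going by the values given here, the one step that bears on changes in this tail is the modest drop a number 20 percentage points lower from compound 1 to compound 3 (beyond the scatter), which says that exchanges here shift the read-out by a moderate amount, and the missing number of compound 2 warns that the tail can also take the result outside the numeric range. On that basis a further downward step is expected for compound 4, a number 18 percentage points lower from compound 3 to compound 4 (beyond the scatter). For compound 4 the value expected in this assay is 55%, with a range from 30% to 80%.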

Compound 4, percent of the compound remaining: 100%
Beside the measured number, compound 4's estimate is 45 percentage points below it; the whole stated range lies below it.
By their numbers in this assay, from the lowest: compound 3; then compounds 1 and 4 (each within the scatter of the next).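

In this assay, among the compounds shown here, the amine nitrogen of the side chain need not carry a carbonyl to give a high read-out: benzyl in place of isopropoxycarbonyl gives a number 27 percentage points higher from compound 3 to compound 4 (beyond the scatter) and is the first upward step seen at this position. Benzyl in place of (tert-butyl)carbamoyl gives a number 7 percentage points higher from compound 1 to compound 4 (within the scatter), so two tails that share neither a carbonyl nor an aromatic ring are not separated by this read-out, and a low number is not tied to tail size or to the presence of a ring. No available measurement accounts for either step.

As far as these compounds go, it remains open whether the high number of compound 4 goes with the aromatic ring or with the carbonyl-free nitrogen; a cyclohexylmethyl or plain isopropyl group on that amine nitrogen would separate the two. Compound 2 still has no number, so its tail cannot be placed in this comparison.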